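A few compounds are considered here, and "the series" means these few. Any claim that something is new, unique, unknown or untested is made for them only; others in the source may bear on it.

Working notes on the series. In a functional assay on DU-145 cells (Homo sapiens) for inhibition, read by MTT assay, with a stated time of 48 h (on this read-out higher numbers stand for weaker inhibition and lower numbers for stronger inhibition), compound 1 `CS(=O)(=O)Nc1ccc(-n2cc(COc3ccccc3Cl)nn2)cc1Oc1ccccc1` gives 21100 nM and compound 2 `Cc1ccc(OCc2cn(-c3ccc(NS(C)(=O)=O)c(Oc4ccccc4)c3)nn2)cc1` gives 8200 nM on the same measure. In this assay compound 3 `CS(=O)(=O)Nc1ccc(-n2cc(OCc3ccccc3)nn2)cc1Oc1ccccc1` gives 10700 nM on that measure, which places it within the scatter of both others, with a 2.0-fold lower number from compound 1 to compound 3 (0.29 log units; within the scatter) on one side and a 1.3-fold higher number from compound 2 to compound 3 (0.12 log units; within the scatter) on the other. Only a 2.6-fold lower number from compound 1 to compound 2 (0.41 log units; beyond the scatter) lies beyond the scatter, and it is modest.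

Compound 4 `Cc1cc(OCc2cn(-c3ccc(NS(C)(=O)=O)c(Oc4ccccc4)c3)nn2)ccc1Cl` is not yet measured. Its difference from compound 3 is (4-chloro-3-methylphenoxy)methyl in place of benzyloxy on an aromatic carbon and amounts to (4-chloro-3-methylphenoxy)methyl in place of benzyloxy on an aromatic carbon of the five-membered aromatic ring with 3 nitrogen.

The closest evidence is the same kind of exchange in the opposite direction, since a 2.0-fold lower number from compound 1 to compound 3 (0.29 log units; within the scatter) and a 1.3-fold higher number from compound 2 to compound 3 (0.12 log units; within the scatter) both stay within the scatter. Compound 4 carries a chloro group as compound 1 does and a methyl group as compound 2 does, and these two examples give no direction. The expected result is a 1.1-fold higher number from compound 3 to compound 4 (0.05 log units; within the scatter) and no step beyond the scatter is expected. In this assay compound 4 is estimated at 12000 nM with an expected range from 5500 nM to 26000 nM for the measurement.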

Compound 4, half-maximal inhibitory concentration: 5900 nM
For compound 4 the middle estimate is 2.0-fold (0.31 log units) above the measured one, within the range that was stated.
By their numbers in this assay, from the lowest: compounds 4, 2, 3 and 1 (each within the scatter of the next, the first and the last beyond it).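

In this assay the exchange of benzyloxy for (4-chloro-3-methylphenoxy)methyl on this aromatic carbon gives a 1.8-fold lower number from compound 3 to compound 4 (0.26 log units; within the scatter) and so stays within the scatter, and the exchange of 4-methylphenyl for 4-chloro-3-methylphenyl on the oxygen gives a 1.4-fold lower number from compound 2 to compound 4 (0.14 log units; within the scatter) and also stays within it. The step of 2-chlorophenyl to 4-chloro-3-methylphenyl on the oxygen gives a 3.6-fold lower number from compound 1 to compound 4 (0.55 log units; beyond the scatter) and is beyond the scatter though modest, so a chloro group in this side group does not by itself go with the number of compound 1, and compound 4 now joins compound 2 in a step beyond the scatter from compound 1, while compound 3 stays within the scatter of compound 1. No measurement available here accounts for any of these steps.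

Open is whether a much larger step can be reached at this position at all, as every group shown is a phenyl ring joined through an oxygen and a single saturated carbon. On these data alone, an amine or a carboxylic acid on that ring, or a longer chain between that ring and the shared core, would test this, and the same exchanges on a different shared core remain equally open.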